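From an Imidazolyl Amidine to a Morpholine Amide

The source may report more compounds than this note shows. Statements on the series, on what has been measured and on what is new or still open speak of the compounds shown alone.

Compound 1, `COc1ccc(-c2nc(/N=C(\N)N(C)C)sc2-c2ccc(OC)cc2)cc1`, gives 37 nM in a functional assay with Oryctolagus cuniculus as the target; on this read-out higher numbers stand for weaker inhibition and lower numbers for stronger inhibition. Compound 2, `COc1ccc(-c2nc(/N=C(\N)n3ccnc3)sc2-c2ccc(OC)cc2)cc1`, reaches only the limit of the assay, > 100 nM. Compound 3, `COc1ccc(-c2nc(CN(C)C)sc2-c2ccc(OC)cc2)cc1`, gives 96 nM in this assay.

Compound 2 therefore stands not at a number but at a limit, (the limit of > 100 nM in this assay, at which 1 of the 3 values shown sits), so its true value may lie anywhere beyond it. Compound 4, `COc1ccc(-c2nc(C(=O)N3CCOCC3)sc2-c2ccc(OC)cc2)cc1`, differs from compound 2 in one place: a group of 8 heavy atoms (5 carbon, 1 nitrogen, 2 oxygen; one six-membered non-aromatic ring with 2 hetero atoms) in place of a group of 8 heavy atoms (4 carbon, 4 nitrogen; one five-membered aromatic ring with 2 hetero atoms), on an aromatic carbon.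

Within the data shown here, three measured steps bear on this change, all at the same aromatic carbon of the shared core. The first is an at least 2.7-fold higher number from compound 1 to compound 2 (0.43 log units; beyond the scatter). The second is a 2.6-fold higher number from compound 1 to compound 3 (0.41 log units; beyond the scatter). The third is an at least 1.0-fold lower number from compound 2 to compound 3 (0.01 log units; that floor lies within the scatter). Taken together, swapping the group on this carbon has moved the number only modestly, and compound 2 and compound 3 both sit near the limit. For a further swap to a group without the amidine, a step that is small or none beyond the scatter is the most reasonable expectation, with some chance that the assay again reports only a limit.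

Compound 4 is thus expected at 150 nM, within a range from 50 nM to 500 nM. That estimate means an expected step that the limit leaves unreadable from compound 2 to compound 4.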

Compound 4, half-maximal inhibitory concentration: < 10 nM
Compound 4 was reported as a limit (the forecaster's own chance of this, stated with the estimate: 45%); middle value at least 15-fold (1.17 log units) from the limit.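

In this assay compound 4 is reported as a limit of the assay, not as a number: the limit of < 10 nM in this assay, at which 1 of the 4 values shown sits. Even so, placing (morpholin-4-yl)carbonyl on this aromatic carbon gives an at least 10-fold lower number from compound 2 to compound 4 (1.00 log units; beyond the scatter) and an at least 9.6-fold lower number from compound 3 to compound 4 (0.98 log units; beyond the scatter) and also an at least 3.7-fold lower number from compound 1 to compound 4 (0.56 log units; beyond the scatter), and each of these floors already lies beyond the scatter. The earlier steps had shown only modest shifts at this carbon, with compound 1 holding the lowest number, whereas these steps show that the same carbon can carry a larger shift and that compound 4 now stands as the most potent of the four compounds.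

The true size of all three steps stays open, since each one gives only a floor and the compounds shown do not tell how far compound 4 lies past its limit. They also do not separate the part played by the carbonyl from that of the morpholine ring, a question that a piperidine amide, a simple dimethylamide or a carboxylic acid on the same carbon could help to settle.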